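Replacing 3-fluoro-4-methoxyphenyl with 3-bromophenyl

The compounds below may be only part of what the source reports. "The series", "measured", "known", "first", "only" and "open" are said of these compounds alone.

In a functional assay on NCI-H460 cells (Homo sapiens) for antiproliferative activity, read by MTT assay, with a stated time of 48 h (a lower number here means a stronger inhibitor, a higher number a weaker inhibitor), compound 1 `COc1cc(-c2cccc3nc(-c4ccccc4)oc23)cc(OC)c1OC` gives 6800 nM. Compound 2 `COc1ccc(-c2nc3cccc(-c4cc(OC)c(OC)c(OC)c4)c3o2)cc1` gives 3500 nM and compound 3 `COc1ccc(-c2nc3cccc(-c4cc(OC)c(OC)c(OC)c4)c3o2)cc1F` gives 2800 nM. Compound 3 shares the low end of these numbers with compound 2, as a 1.3-fold lower number from compound 2 to compound 3 (0.10 log units; within the scatter) shows. It stands clear of compound 1, with a 2.4-fold lower number from compound 1 to compound 3 (0.39 log units; beyond the scatter).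

Compound 4 `COc1cc(-c2cccc3nc(-c4cccc(Br)c4)oc23)cc(OC)c1OC` differs from compound 3 by one change: 3-bromophenyl in place of 3-fluoro-4-methoxyphenyl on an aromatic carbon. Among the compounds with values here, no measured compound carries bromine, so the evidence is indirect. Adding the methoxy alone gave a 1.9-fold lower number from compound 1 to compound 2 (0.29 log units; within the scatter), and adding both the methoxy and the fluoro gave a 2.4-fold lower number from compound 1 to compound 3 (0.39 log units; beyond the scatter). As far as these compounds go, compound 4 has neither group, which suggests a small move back towards compound 1, though its bromine remains untested. In this assay a step beyond the scatter is therefore not firmly expected, and any step should be towards a higher number. The expected change is a 1.6-fold higher number from compound 3 to compound 4 (0.21 log units; within the scatter). For compound 4 the estimated value is 4500 nM, with an expected range from 1800 nM to 10000 nM.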

Compound 4, half-maximal inhibitory concentration: 3800 nM
Compound 4: the middle estimate sits 1.2-fold (0.07 log units) above what was measured; the measured number falls inside the stated range.
By their numbers in this assay, from the lowest: compounds 3, 2, 4 and 1 (each within the scatter of the next, the first and the last beyond it).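

In this assay, 3-bromophenyl on the aromatic carbon next to the ring nitrogen and ring oxygen cannot be told apart from 3-fluoro-4-methoxyphenyl (a 1.4-fold higher number from compound 3 to compound 4 (0.13 log units; within the scatter)) or from 4-methoxyphenyl (a 1.1-fold higher number from compound 2 to compound 4 (0.04 log units; within the scatter)), so a methoxy on this phenyl ring is not required for a number within the scatter of compound 3. Bromo in place of hydrogen also stays within the scatter of the plain phenyl (a 1.8-fold lower number from compound 1 to compound 4 (0.25 log units; within the scatter)), which leaves compound 3 as the only one of these compounds set clearly apart from compound 1. Nothing available explains why these groups give such similar numbers.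

The compounds shown leave open whether bromine elsewhere on the phenyl ring would give a similar number. They also leave open how an amine or a carboxylic acid on this ring would read.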